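Restoring methoxy to the weakest compound in the series

A few compounds are considered here, and "the series" means these few. Any claim that something is new, unique, unknown or untested is made for them only; others in the source may bear on it.

compound 1 `COc1ccc(NC(=O)C2(C(=O)Nc3ccc(Nc4ncc5cc(C(=O)N(C)C)n(C6CCCC6)c5n4)cc3)CC2)cc1` 76.4%
compound 2 `CN(C)C(=O)c1cc2cnc(Nc3ccc(NC(=O)C4(C(=O)Nc5ccc(Br)cc5)CC4)cc3)nc2n1C1CCCC1` 21.1%
compound 3 `CN(C)C(=O)c1cc2cnc(Nc3ccc(NC(=O)C4(C(=O)Nc5cccc(C(F)(F)F)c5)CC4)cc3)nc2n1C1CCCC1` 9.7%

In a functional assay on T47D cells (Homo sapiens) for inhibition, read by CCK-8 assay, with a stated time of 72 h, tested at 1 uM (on this read-out higher numbers stand for more inhibition of growth at the one concentration tested and lower numbers for less inhibition of growth), compound 3 stands at 9.7% as the lowest of the three. Compound 4 `COc1cccc(NC(=O)C2(C(=O)Nc3ccc(Nc4ncc5cc(C(=O)N(C)C)n(C6CCCC6)c5n4)cc3)CC2)c1` differs from it by methoxy in place of trifluoromethyl on an aromatic carbon and so carries methoxy in place of trifluoromethyl on an aromatic carbon, meta to a large group. Within the data shown here, three measured steps bear on this change. The record shows a number 55.3 percentage points lower from compound 1 to compound 2 (beyond the scatter) and a number 66.7 percentage points lower from compound 1 to compound 3 (beyond the scatter) as large falls, while a number 11.4 percentage points lower from compound 2 to compound 3 (beyond the scatter) is modest. Among the measured compounds shown here, compound 1, the only measured methoxy compound, gives 76.4% and so points upward, yet no measured compound carries 3-methoxyphenyl. A large upward step is therefore expected, estimated as a number 30.3 percentage points higher from compound 3 to compound 4 (beyond the scatter) and short of the full distance. Compound 4 is estimated at 40% with 15% to 70% as the expected range.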

Compound 4, percent growth inhibition at one concentration: 56.3%
Compound 4: middle estimate off by 16.3 percentage points, on the low side; low and high end bracket the measured number.
By their numbers in this assay, from the lowest: compound 3; then compound 2; then compound 4; then compound 1.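

In this assay the exchange of trifluoromethyl for methoxy, meta to a large group, gives a number 46.6 percentage points higher from compound 3 to compound 4 (beyond the scatter) and the exchange of 4-bromophenyl for 3-methoxyphenyl gives a number 35.2 percentage points higher from compound 2 to compound 4 (beyond the scatter) so high inhibition is not confined to 4-methoxyphenyl. Where methoxy sits still counts, with a number 20.1 percentage points lower from compound 1 to compound 4 (beyond the scatter) as a modest step between the two methoxy isomers. Nothing available explains these differences.

From the compounds shown here alone, whether a hydroxy or an ethoxy group on this aromatic carbon would keep the gain remains open. So does the effect of 2-methoxyphenyl on the same amide nitrogen.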